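The source may report more compounds than this note shows. Statements on the series, on what has been measured and on what is new or still open speak of the compounds shown alone.

Compound 1 `C=CC(=O)Nc1cc2c(Nc3ccc(F)c(Cl)c3)ncnc2cc1OCc1cn(CCCCC(=O)NO)nn1` carries a hydroxamic acid on a chain hung from the triazole of the shared core. In a functional assay on A549 cells (Homo sapiens) for antiproliferative activity, read by MTT assay, with a stated time of 72 h (on this read-out higher numbers stand for weaker inhibition and lower numbers for stronger inhibition), compound 1 gives only a limit, > 50000 nM. Compound 2 `C=CC(=O)Nc1cc2c(Nc3ccc(OCc4cccc(F)c4)c(Cl)c3)ncnc2cc1OCc1cn(CCCCC(=O)NO)nn1` also gives only a limit in this assay, > 50000 nM. The step that the two limits leave unreadable from compound 1 to compound 2 therefore cannot be sized, and the limit of > 50000 nM in this assay, at which 2 of the 2 values shown sit, is all the series shows. Compound 3 `C=CC(=O)Nc1cc2c(Nc3ccc(F)c(Cl)c3)ncnc2cc1OCc1cn(CCCC(=O)NO)nn1` differs from compound 1 by hydroxycarbamoyl in place of (hydroxycarbamoyl)methyl on a saturated chain carbon, three bonds along the chain from an aromatic nitrogen. Among the measured compounds shown here, no measured step bears on this chain shortening, so no direction beyond the scatter can be expected. Compound 3 is therefore estimated at 60000 nM, range 15000 nM to 250000 nM, a step that the limit leaves unreadable from compound 1 to compound 3 that is most likely to appear again as a limit.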

Compound 3, half-maximal inhibitory concentration: > 50000 nM
Compound 3 was reported as a limit; the forecaster's own chance of this, stated with the estimate: 80%; the middle value lies beyond the limit too.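

Compound 3, like compound 1, gives only a limit in this assay, so no step between compound 1 and compound 3 can be read: the limit of > 50000 nM in this assay, at which 3 of the 3 values shown sit.

The compounds shown leave open whether either change, in the chain or on the aromatic carbon, alters the activity in this assay.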